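From Fluoro to Bromo on an Aromatic Carbon

The source may report more compounds than this note shows. Statements on the series, on what has been measured and on what is new or still open speak of the compounds shown alone.

In a functional assay on MOLT-4 cells (Homo sapiens) for inhibition (on this read-out lower numbers stand for stronger inhibition and higher numbers for weaker inhibition), compound 1 `COc1cccc(/C=C2\Cc3ccccc3C2=O)c1` is reported as > 500000 nM, which is a limit of the assay and not a number. Compound 2 `O=C1/C(=C/c2cccc(F)c2)CCc2ccccc21` gives 11900 nM. Compound 3 `O=C1/C(=C/c2ccc(F)cc2)CCc2ccccc21` gives 41200 nM, the higher of the two numbers, and its gap to compound 2 lies beyond the scatter. Compound 4 `O=C1/C(=C/c2ccc(Br)cc2)CCc2ccccc21` has bromo in place of fluoro on an aromatic carbon, para to a large group (bromo in place of fluoro on an aromatic carbon). Among the compounds with values here, no measured pair shows this exchange, so the expectation is loose. The estimated 1.5-fold lower number from compound 3 to compound 4 (0.18 log units; within the scatter) is a small move toward stronger inhibition in this assay, hardly beyond the scatter. For compound 4 the expected value is 27000 nM, with an estimated range of 8000 nM to 90000 nM.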

Compound 4, half-maximal inhibitory concentration: > 500000 nM
Compound 4 was reported as a limit (the forecaster's own chance of this, stated with the estimate: 7%); middle value at least 18-fold (1.26 log units) away from the limit.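

Bromo in place of fluoro, on an aromatic carbon para to a large group, brings an at least 12-fold higher number from compound 3 to compound 4 (1.08 log units; beyond the scatter) in this assay, so the two halogens are not interchangeable at this position. The reading for compound 4 is a limit of the assay and not a number, so the full size of the step stays unknown, and compound 4 is not alone there: the limit of > 500000 nM in this assay, at which 2 of the 4 values shown sit.

The compounds shown leave open whether chloro at this position would keep the inhibition seen with compound 3 or reach the limit as compound 4 does. They also leave open how an amine or a carboxylic acid would behave there.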